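Quinoline ether amides: HepG2 cell toxicity, chloro for methoxy

This account rests on a few compounds, and the source may have more. Where it says the series, first, only, none or still open, it means among the compounds named here.

Measured compounds:
compound 1 `COc1ccc2nc(C)cc(OCc3ccc4ccccc4n3)c2c1` — 31600 nM
compound 2 `COc1ccc2nc(C)cc(OCC(=O)Nc3cccc(C)c3)c2c1` — 39800 nM
compound 3 `COc1ccc(NC(=O)COc2cc(C)nc3ccc(OC)cc23)cc1` — > 100000 nM

In a toxicity assay on HepG2 cells (Homo sapiens) for inhibition, read by CellTiter-Glo, with a stated time of 48 h (on this read-out higher numbers stand for weaker inhibition and lower numbers for stronger inhibition), compound 1 gives 31600 nM and compound 2 gives 39800 nM; these two values lie within the usual scatter of each other. For compound 3 this assay reports only a limit, > 100000 nM, not a number. That value sits at the limit of > 100000 nM in this assay, at which 1 of the 3 values shown sits. Within the data shown here, the only measured change at the amide-type nitrogen is an at least 2.5-fold higher number from compound 2 to compound 3 (0.40 log units; beyond the scatter); since compound 3 stands at a limit, the true size of that step is known only as a lower bound.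

Compound 4 `COc1ccc2nc(C)cc(OCC(=O)Nc3ccc(Cl)cc3)c2c1` differs from compound 3 by chloro in place of methoxy on an aromatic carbon. Among the measured compounds shown here, no measured step covers chloro in place of methoxy, so the expectation rests on the spread between compound 2 and compound 3 alone. Compound 4 is expected to fall between the value of compound 2 and the limit reached by compound 3, a step of an at least 1.6-fold lower number from compound 3 to compound 4 (0.22 log units; that floor lies within the scatter) back toward numbers that this assay can resolve. The estimate for compound 4 in this assay is 60000 nM, with an expected range from 25000 nM to 150000 nM, and a real chance that only a limit is returned again.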

Compound 4, half-maximal inhibitory concentration: > 100000 nM
Compound 4: only a limit was reported (the forecaster's own chance of this, stated with the estimate: 35%); middle value at least 1.6-fold (0.22 log units) from the limit.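

In this assay compound 4 returns only a limit, > 100000 nM, so chloro in place of methoxy, para to a large group, does not bring the number back into the readable range. The step from compound 2 to the 4-chlorophenyl amide is an at least 2.5-fold higher number from compound 2 to compound 4 (0.40 log units; beyond the scatter), and the step between the two limits cannot be read. Methoxy and chloro at this place thus end at the same ceiling, and the change gives no ranking of the two groups: the limit of > 100000 nM in this assay, at which 2 of the 4 values shown sit.

As far as these compounds go, the true distance separating compound 3 and compound 4 stays open, as does any order between them. Also open, from the compounds shown here alone, is whether an amine or a carboxylic acid at this place on the ring would return a number that this assay can resolve.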